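The source may hold more compounds than are shown below. What is called first, only, known or untested is meant among the compounds shown, and "the series" means these compounds.

Measured in a functional assay on DU-145 cells (Homo sapiens) for inhibition, read by trypan blue exclusion, with a stated time of 96 h; a higher number here means a weaker inhibitor of growth, a lower number a stronger inhibitor of growth:

- Compound 1 `Cc1ccc(CS/C(=C/c2c[nH]c3ccc(Br)cc23)C(=O)c2ccc(Cl)cc2)cc1`: 1000 nM
- Compound 2 `O=C(/C(=C\c1ccc(Cl)cc1)SCc1ccc(F)cc1)c1ccc(Cl)cc1`: 10000 nM

Of these two compounds, compound 2 has the higher number, 10000 nM, which makes it the weaker inhibitor of growth. Compound 1 lies lower at 1000 nM, a gap beyond the scatter of repeat measurements. For the measured compounds named here, no two measured compounds differ in one place only, so no measured step shows directly what a single change does here.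

Compound 3 `Cc1ccc(CS/C(=C/c2ccc(Cl)cc2)C(=O)c2ccc(Cl)cc2)cc1` comes from compound 2 by one change: methyl in place of fluoro on an aromatic carbon. In other words, 4-fluorobenzyl becomes 4-methylbenzyl. The swap is small, so no step beyond the scatter is expected in this assay, with at most a slight lean towards a lower number. Compound 1, at 1000 nM, also carries 4-methylbenzyl, but it differs elsewhere too, so it is only a weak hint. The expected change is a 1.4-fold lower number from compound 2 to compound 3 (0.15 log units; within the scatter). For compound 3 the estimated value is 7000 nM, with an expected range of 2000 nM to 20000 nM.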

Compound 3, concentration for 50% growth inhibition: 10000 nM
The estimate for compound 3 lay 1.4-fold (0.15 log units) below the measured number; the measured number falls inside the stated range.
By their numbers in this assay, from the lowest: compound 1; then compounds 2 and 3 (each within the scatter of the next).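

In this assay, 4-methylbenzyl in place of 4-fluorobenzyl gives no change at the digits printed from compound 2 to compound 3 (within the scatter), so with 4-chlorophenyl on the double bond, this assay does not separate fluoro from methyl on this aromatic carbon. For the compounds shown here, the new compound also provides the first comparison that isolates the other end of the molecule: with 4-methylbenzyl held constant, 4-chlorophenyl in place of 5-bromo-1H-indol-3-yl gives a 10-fold higher number from compound 1 to compound 3 (1.00 log units; beyond the scatter), a difference beyond the scatter that the change at the benzyl group did not produce. No measurement here explains why either change has the size it has.

Fluoro and methyl are only two small groups, so it remains open whether something quite different on this aromatic carbon, such as an amine, a carboxylic acid or a longer chain, would also leave the number unchanged. As far as these compounds go, it is also open whether the bromine or the rest of the 5-bromo-1H-indol-3-yl group accounts for the step, and whether fluoro and methyl would still match when that group is present.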